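Cyano for Chloro on the Thiazole: Solubility Outlook

The source may report more compounds than this note shows. Statements on the series, on what has been measured and on what is new or still open speak of the compounds shown alone.

Measured so far in a physicochemical assay for solubility, read by nephelometry, at pH 2; on this read-out higher numbers stand for higher solubility and lower numbers for lower solubility:
Compound 1 `N#Cc1cnc(NC(=O)N2CCN(c3ccc(Cl)c(Cl)c3)CC2)s1` gives < 1600 nM, which is a limit of the assay.
Compound 2 `Cc1cc(NC2CCN(C(=O)Nc3ncc(Cl)s3)C2)ccc1Cl` gives 6300 nM.
Compound 3 `O=C(Nc1ncc(Cl)s1)N1CCN(c2cnc(Cl)c(Cl)c2)CC1` gives < 1600 nM, which is again a limit of the assay.

Compound 3 thus stands at a limit in this assay rather than at a number, and a second value among the three shown is a limit as well (the limit of < 1600 nM in this assay, at which 2 of the 3 values shown sit). Only compound 2 gives a number in this assay. Among the compounds with values here, no two measured compounds differ in a single place, so no measured step can be read from them. Compound 4 `N#Cc1cnc(NC(=O)N2CCN(c3cnc(Cl)c(Cl)c3)CC2)s1` differs from compound 3 by cyano in place of chloro on an aromatic carbon, on the five-membered aromatic ring with one nitrogen and one sulfur. Compound 1 carries the same cyano group on that ring and sits at the limit (the limit of < 1600 nM in this assay, at which 2 of the 3 values shown sit). A step of no size beyond the scatter is therefore expected, with compound 4 remaining at the limit. Compound 4 is estimated at 1000 nM, with a range from 300 nM to 3000 nM. The expected step that the limit leaves unreadable from compound 3 to compound 4 is estimated to lie within the scatter.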

Compound 4, solubility: < 1600 nM
Compound 4 ended at the assay's limit (the forecaster's own chance of this, stated with the estimate: 70%); the middle value does not contradict the limit.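

In this assay the steps from compound 3 to compound 4 and from compound 1 to compound 4 cannot be read, since all three compounds sit at the same limit of the assay: the limit of < 1600 nM in this assay, at which 3 of the 4 values shown sit. On these data alone, how far under that limit each of the three lies remains open.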